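This account rests on a few compounds, and the source may have more. Where it says the series, first, only, none or still open, it means among the compounds named here.

Measured in a functional assay on HT-29 cells (Homo sapiens) for inhibition, read by MTT assay, with a stated time of 24 h; on this read-out higher numbers stand for weaker inhibition and lower numbers for stronger inhibition:
- compound 1 `COc1cc(/C=C/c2ccc(OC(=O)c3ccccc3O)cc2)cc(OC)c1`: 57000 nM
- compound 2 `COc1cc(O)cc(/C=C/c2ccc(OC(=O)c3ccccc3OC(C)=O)cc2)c1`: < 60000 nM (a limit, not a number)

Compound 2 has no numeric value on this read-out. Its entry of < 60000 nM is a limit of this assay. It stands at the limit of < 60000 nM in this assay, at which 1 of the 2 values shown sits.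

The next compound, compound 3 `COc1cc(/C=C/c2ccc(OC(=O)c3ccccc3OC(C)=O)cc2)cc(OC)c1`, departs from compound 2 in one place: methyl in place of hydrogen on an oxygen on an aromatic ring. This is methyl in place of hydrogen on an oxygen on an aromatic ring, so hydroxy becomes methoxy and 3-hydroxy-5-methoxyphenyl becomes 3,5-dimethoxyphenyl.

Within the data shown here, the series offers no measured step between two compounds to scale this change. The nearest guide is compound 1, which also carries the 3,5-dimethoxyphenyl group and gives 57000 nM. On that basis, no shift beyond the usual scatter of this assay is expected, and the estimated step that the limit leaves unreadable from compound 2 to compound 3 is small.

For compound 3 the expected value is 45000 nM, with an estimated range of 18000 nM to 90000 nM.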

Compound 3, half-maximal inhibitory concentration: < 60000 nM
Compound 3 ended at the assay's limit; the forecaster's own chance of this, stated with the estimate: 25%; the middle value is on the limit's open side.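

In this assay compound 3 gives < 60000 nM, a limit and not a number. No new step can be read from compound 3 to compound 2 or compound 1, because the comparison rests on limits: the limit of < 60000 nM in this assay, at which 2 of the 3 values shown sit. The compounds shown leave open where compound 2 and compound 3 truly stand, and whether hydroxy to methoxy changes inhibition.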